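The source may hold more compounds than are shown below. What is called first, only, known or untested is meant among the compounds shown, and "the series" means these compounds.

Working notes on the series, read in a functional assay on the whole organism for antagonist activity, with Mus musculus as the target; a higher number here means that more compound is needed for the effect, a lower number that less compound is needed. Within the data shown here, compound 1 `CCC(=O)N(c1ccc(Cl)cc1)C1CCCC1N(C)C` gives 0.2 mg/kg and sets the low end of the numbers so far. Compound 2 `CCC(=O)N(c1ccc(Cl)cc1)C1CCCCC1N(C)C` gives 17 mg/kg in this assay, a much higher number than compound 1 and a gap well beyond the scatter. Compound 3 `CCC(=O)N(c1ccc(OC)cc1)C1CCCC1N(C)C` gives 20 mg/kg; 20 mg/kg (2 entries) on repeated entries, within the scatter of compound 2.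

Compound 4 `CCC(=O)N(c1ccc(OC)cc1)C1CCCCC1N(C)C` is not yet measured. Its change from compound 2 is methoxy in place of chloro on an aromatic carbon is the whole difference.

Among the measured compounds shown here, no measured step covers this change directly. The nearest evidence is one pair: the chloro compound 1 gives 0.2 mg/kg while the methoxy compound 3 gives 20 mg/kg; 20 mg/kg (2 entries) on the shared core of those two. A single pair is thin support, so the same direction is expected here, with a smaller size. The expected change is a 4.1-fold higher number from compound 2 to compound 4 (0.61 log units; beyond the scatter) as a rise beyond the scatter. For compound 4 the estimate is 70 mg/kg with an expected range of 20 mg/kg to 300 mg/kg in this assay.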

Compound 4, dose for half-maximal effect: > 50 mg/kg
Compound 4 ended at the assay's limit; the forecaster's own chance of this, stated with the estimate: 35%; the middle value lies beyond the limit too.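

In this assay compound 4 gives > 50 mg/kg, which is a limit of the assay and not a number. On the core of compound 2, methoxy in place of chloro on an aromatic carbon, para to a large group, gives an at least 2.9-fold higher number from compound 2 to compound 4 (0.46 log units; beyond the scatter). The earlier compounds showed this change only on a different core, where compound 1 gives 0.2 mg/kg and compound 3 gives 20 mg/kg; 20 mg/kg (2 entries), so the higher number with methoxy now appears on both cores, and no compound shown goes against it.

From the compounds shown here alone, how far the number rises on this core stays unread because only a bound is available: the limit of > 50 mg/kg in this assay, at which 1 of the 4 values shown sits. Whether other groups at this place, such as an amine, a nitrile or a longer ethoxy chain, would give numbers nearer those of chloro or of methoxy remains open.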